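Bromo for hydrogen on the core of compound 2

A few compounds are considered here, and "the series" means these few. Any claim that something is new, unique, unknown or untested is made for them only; others in the source may bear on it.

Working notes on a small set tested in a functional assay on HCT-116 cells (Homo sapiens) for cytotoxicity, with a stated time of 3 days; a lower number here means a stronger inhibitor, a higher number a weaker inhibitor. Compound 1 `C#Cc1sc(-c2ccc(F)cc2)nc1C(=O)OCC` gives > 40000 nM, which is a limit of the assay and not a number. Compound 2 `c1ccc2[se]cnc2c1` likewise gives > 40000 nM, again a limit. Compound 3 `Brc1nc2ccccc2o1` gives > 40000 nM, also a limit. Compound 2 therefore stands nowhere on a scale of numbers: its value is a limit, and the two other values in this assay are limits as well, all three sitting at the limit of > 40000 nM in this assay, at which 3 of the 3 values shown sit. Among the compounds with values here, no step between measured compounds can be drawn.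

The unmeasured compound 4 `Brc1nc2ccccc2[se]1` differs from compound 2 by bromo in place of hydrogen on an aromatic carbon. Within the data shown here, with no measured step to lean on, and with compound 3 > 40000 nM showing that a bromo substituent on a closely related core does not by itself bring a value into the numeric range, the expectation is no step beyond the scatter, an estimated step that the limit leaves unreadable from compound 2 to compound 4. Compound 4 is expected to give about 60000 nM, within 20000 nM to 200000 nM, most likely reported as a limit.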

Compound 4, half-maximal inhibitory concentration: > 40000 nM
Compound 4: only a limit was reported; the forecaster's own chance of this, stated with the estimate: 85%; the middle value does not contradict the limit.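

No step can be read from compound 2 to compound 4, because both carry only a limit and not a number: the limit of > 40000 nM in this assay, at which 4 of the 4 values shown sit.

The compounds shown leave open whether bromo in place of hydrogen on this core changes the half-maximal inhibitory concentration at all.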